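The source may hold more compounds than are shown below. What is called first, only, known or untested is meant among the compounds shown, and "the series" means these compounds.

Three compounds of the series have numbers in a functional assay on MCF7 cells (Homo sapiens) for inhibition, read by sulforhodamine B assay, with a stated time of 48 h, tested at 50 uM; a higher number here means more inhibition of growth at the concentration tested, a lower number less inhibition of growth. Compound 1 `COc1cc2c(cc1CC=C(C)C)C(=O)C[C@@H](c1ccc(Oc3ccc(F)cc3)cc1)O2` gives 37%. Compound 2 `C#CCO/N=C1/C[C@@H](c2ccc(OC)cc2)Oc2cc(OC)c(CC=C(C)C)cc21` gives 61%. Compound 3 `COc1ccc([C@@H]2C/C(=N/OCc3cn(-c4ccc(C(=O)c5ccccc5)cc4)nn3)c3cc(CC=C(C)C)c(OC)cc3O2)cc1` gives 41%, the second highest of the three numbers; its number lies within the scatter of that of compound 1, and it sits below that of compound 2 by a margin beyond the scatter. Within the data shown here, no pair among the measured compounds differs in only one place, so no measured step is available for the change now in question.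

Compound 4 `COc1ccc([C@@H]2C/C(=N/OCc3cn(-c4ccc(NC(=O)c5ccccc5)cc4)nn3)c3cc(CC=C(C)C)c(OC)cc3O2)cc1` differs from compound 3 in one place: benzamido in place of benzoyl on an aromatic carbon. The measured set holds nothing that shows how a change of this kind moves the number in this assay, so the expectation rests on the value of compound 3 alone. The expected step in this assay is a number 3 percentage points higher from compound 3 to compound 4 (within the scatter), which would stay within the scatter. Compound 4 is therefore estimated at 44%, with a range from 25% to 65%.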

Compound 4, percent growth inhibition at one concentration: 4%
Compound 4: middle estimate off by 40 percentage points, on the high side, and the stated range ends above it.
By their numbers in this assay, from the lowest: compound 4; then compounds 1 and 3 (each within the scatter of the next); then compound 2.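

In this assay, benzamido in place of benzoyl on an aromatic carbon, para to a large group, gives a number 37 percentage points lower from compound 3 to compound 4 (beyond the scatter). Among these compounds, this is the first single-place step, and it shows that the number is highly sensitive to the group at this carbon, even though both groups carry the same carbon-only six-membered aromatic ring. The entering group adds a nitrogen and a hydrogen-bond donor, but nothing available explains why the number falls.

The compounds shown leave open whether a benzyl group, or a benzamido group with a methyl on its nitrogen, would give a number closer to that of compound 3 or of compound 4. Among the compounds shown here, with only one pair, it also remains open whether this step carries over to other compounds.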